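The compounds below may be only part of what the source reports. "The series", "measured", "known", "first", "only" and "open" are said of these compounds alone.

Measured compounds:
- compound 1, `ClCc1ccc(Cn2cnc3nc(Cl)nc(Cl)c32)cc1`, 3310 nM
- compound 2, `ClCc1ccccc1Cn1cnc2ncnc(Cl)c21`, 2230 nM
- compound 3, `ClCc1ccccc1Cn1cnc2nc(Cl)nc(Cl)c21`, 250 nM

All three values come from a functional assay on K562 cells (Homo sapiens) for cytotoxicity, read by sulforhodamine B assay, with a stated time of 48 h; on this read-out lower numbers stand for stronger inhibition of growth and higher numbers for weaker inhibition of growth. Compound 3 gives 250 nM and compound 2 gives 2230 nM; the step between them, an 8.9-fold higher number from compound 3 to compound 2 (0.95 log units; beyond the scatter), is the change (hydrogen in place of chloro on an aromatic carbon). Compound 1 carries the same chloro pattern as compound 3 on a core whose difference from that of compound 3 is not broken down here; in this assay compound 1 gives 3310 nM. Its values against compound 2 lie within the scatter, so no order is read between those two.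

Compound 4, `ClCc1ccc(Cn2cnc3ncnc(Cl)c32)cc1`, has not been measured in this assay. It stands to compound 1 as compound 2 stands to compound 3: the change (hydrogen in place of chloro on an aromatic carbon). The place description is the same word for word in both pairs, so the change is the same. Within the data shown here, only one measured instance of it exists, so the expectation rests on a single step.

Compound 4 is expected to give a higher number than compound 1 in this assay, with a step of about a 4.5-fold higher number from compound 1 to compound 4 (0.66 log units; beyond the scatter), because the same change produced an 8.9-fold higher number from compound 3 to compound 2 (0.95 log units; beyond the scatter). The step is estimated somewhat smaller than that one, since compound 1 already starts from the highest measured number and the assay may not resolve much weaker growth inhibition. Compound 4 is estimated at 15000 nM, likely between 5000 nM and 50000 nM.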

Compound 4, concentration for 50% growth inhibition: 3010 nM
Beside the measured number, compound 4's estimate is 5.0-fold (0.70 log units) above it; measured number outside the range, below it.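

In this assay, hydrogen in place of chloro on the aromatic carbon between two ring nitrogen atoms gives a 1.1-fold lower number from compound 1 to compound 4 (0.04 log units; within the scatter), so on the core of compound 1 this chloro group makes no readable difference to growth inhibition. The size of the step therefore does not carry over from one core to the other, and the single earlier step is no reliable guide to the same change on a different core in this series: the same change on two cores in this assay, an 8.9-fold higher number (0.95 log units; beyond the scatter) from compound 3 to compound 2 and a 1.1-fold lower number (0.04 log units; within the scatter) from compound 1 to compound 4, 9.8-fold (0.99 log units) apart, beyond the scatter of two such steps

Among these compounds, this rests on only two matched pairs, and it does not show which structural feature of the two cores sets the gap, how the change would behave on a third core, or whether either step would hold in another cell line or at another exposure time.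

All four compounds shown carry a chloromethyl group and a further chloro group on the shared ring system, so it remains open whether growth inhibition in either pair depends on these groups, for instance with hydroxymethyl or a plain methyl in place of chloromethyl. From the compounds shown here alone, it is also open how an amine, a methoxy group or a longer chain at the carbon between the two ring nitrogen atoms would read on each core.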